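A few compounds are considered here, and "the series" means these few. Any claim that something is new, unique, unknown or untested is made for them only; others in the source may bear on it.

Compound 1 `CCOC(=O)C1C(=O)C=C(Nc2ccc(N3CCN(C)CC3)cc2)CC1c1ccccc1` gives 4.39 in a physicochemical assay for lipophilicity; on this read-out higher numbers stand for higher lipophilicity and lower numbers for lower lipophilicity.
Compound 2 `CCN1CCN(c2ccc(NC3=CC(=O)C(C(=O)OC)C(C)C3)cc2)CC1` gives 3.07 in this assay.

Of these two, compound 1 holds the higher number in this assay, and its gap to compound 2 lies beyond the usual scatter. Compound 3 `CCOC(=O)C1C(=O)C=C(Nc2ccc(N3CCN(CC)CC3)cc2)CC1c1ccccc1` has not yet been measured in this assay. It differs from compound 1 in one place: methyl in place of hydrogen on a saturated chain carbon bound to an amine nitrogen in a ring. Among the measured compounds shown here, no pair of measured compounds shows this single change on its own, so its effect here is not known from the data. The expected step is a number 0.41 log units higher from compound 1 to compound 3 (beyond the scatter), a modest rise in this assay that should fall just beyond the scatter. Compound 3 is estimated at 4.8, within a range from 4.4 to 5.2.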

Compound 3, partition coefficient: 4.77
Estimate against measurement, compound 3: 0.03 log units above; the measured number falls inside the stated range.
By their numbers in this assay, from the lowest: compound 2; then compound 1; then compound 3.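

Among the compounds shown here, replacing 4-methylpiperazin-1-yl with 4-ethylpiperazin-1-yl on the core of compound 1 gives the first direct reading of this single change: in this assay there is a number 0.38 log units higher from compound 1 to compound 3 (beyond the scatter), a modest step. One added methyl, on a saturated chain carbon bound to an amine nitrogen in a ring, is therefore enough to move this read-out past the usual scatter. Nothing in the data explains the rise. Going by these compounds, whether a longer chain such as propyl would extend the rise remains open, as does whether the same step would appear on the core of compound 2.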